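Methoxy for chloro on the lactam-bearing ring

A few compounds are considered here, and "the series" means these few. Any claim that something is new, unique, unknown or untested is made for them only; others in the source may bear on it.

Measured compounds:
compound 1 `COc1cc2c(/C=C3/C(=O)Nc4ccc(O)cc43)c(Cl)n(Cc3cc(OC)c(OC)c(OC)c3)c2cc1C` gives 34700 nM in a functional assay on cells (Cancer cell lines, Homo sapiens) for cytotoxicity, with a stated time of 48 h; on this read-out higher numbers stand for weaker inhibition of growth and lower numbers for stronger inhibition of growth
compound 2 `COc1cc2c(/C=C3/C(=O)Nc4ccc(Cl)cc43)c(Cl)n(Cc3cc(OC)c(OC)c(OC)c3)c2cc1C` gives 6030 nM in this assay
compound 3 `COc1cc2c(/C=C3/C(=O)Nc4cccc(Cl)c43)c(Cl)n(Cc3cc(OC)c(OC)c(OC)c3)c2cc1C` gives 12600 nM in this assay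

Compound 2 stands at the lowest of the three numbers; compound 3 comes nearest, as a 2.1-fold higher number from compound 2 to compound 3 (0.32 log units; beyond the scatter) shows, and compound 1 lies furthest away, as a 5.8-fold lower number from compound 1 to compound 2 (0.76 log units; beyond the scatter) shows. Compound 4 `COc1ccc2c(c1)/C(=C\c1c(Cl)n(Cc3cc(OC)c(OC)c(OC)c3)c3cc(C)c(OC)cc13)C(=O)N2` differs from compound 2 by methoxy in place of chloro on an aromatic carbon. Going by the values given here, no measured pair exchanges chloro for methoxy, so the step from compound 1 to compound 2, which replaced hydroxy with chloro at this carbon and brought a 5.8-fold lower number from compound 1 to compound 2 (0.76 log units; beyond the scatter), is the only one that touches the same place. That step points to a substituent change here moving the number modestly, and a return toward an oxygen-bearing group is expected to move it upward rather than down. Compound 4 is therefore estimated at 12000 nM, within 5000 nM to 30000 nM. The expected step from compound 2 to compound 4 is a 2.0-fold higher number from compound 2 to compound 4 (0.30 log units; within the scatter).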

Compound 4, concentration for total growth inhibition: 75900 nM
The estimate for compound 4 lay 6.3-fold (0.80 log units) below the measured number; measured number outside the range, above it.
By their numbers in this assay, from the lowest: compound 2; then compound 3; then compound 1; then compound 4.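

In this assay, chloro to methoxy on this aromatic carbon gave a 13-fold higher number from compound 2 to compound 4 (1.10 log units; beyond the scatter), a large step that goes well past the modest change seen earlier at the same carbon, a 5.8-fold lower number from compound 1 to compound 2 (0.76 log units; beyond the scatter). Methyl in place of hydrogen on the oxygen also counted, giving a 2.2-fold higher number from compound 1 to compound 4 (0.34 log units; beyond the scatter), so at this carbon chloro carries the lowest number, hydroxy a higher one and methoxy the highest. Nothing at hand accounts for this order of the groups.

From the compounds shown here alone, it remains open whether an amine, fluoro or a longer ether chain such as ethoxy at this carbon would fall nearer to chloro or to methoxy. Going by these compounds, it is also open whether methoxy would raise the number as sharply on the carbon where compound 3 carries its chloro.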